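Acetoxy in Place of Hydrogen on the Benzoate Ring

A few compounds are considered here, and "the series" means these few. Any claim that something is new, unique, unknown or untested is made for them only; others in the source may bear on it.

Of the compounds shown here, three have so far been measured in an ADME assay on a cell-free system (plasma, Homo sapiens) for metabolic stability; a lower number here means that the compound disappears faster, a higher number that the compound lasts longer. Compound 1 `CCOC(=O)c1ccc(/N=N/N(C)C(=O)OCOC(=O)c2ccccc2O)cc1` gives 0.567 h, compound 2 `CCOC(=O)c1ccc(/N=N/N(C)C(=O)OCOC(=O)c2ccccc2)cc1` gives 0.783 h, and compound 3 `CCCCC(=O)OCOC(=O)Cc1c(C)n(C(=O)c2ccc(Cl)cc2)c2ccc(OC)cc12`, built on a different core, gives 2.07 h. Compound 2 stands second highest of the three numbers; compound 3 lies furthest from it, beyond the scatter, and compound 1 nearest. Among the compounds with values here, the only step between two compounds that differ in one place is a 1.4-fold higher number from compound 1 to compound 2 (0.14 log units; within the scatter), hydrogen in place of hydroxy on an aromatic carbon.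

Compound 4 `CCOC(=O)c1ccc(/N=N/N(C)C(=O)OCOC(=O)c2ccccc2OC(C)=O)cc1` differs from compound 2 in exactly one place: acetoxy in place of hydrogen on an aromatic carbon. Within the data shown here, no measured compound carries an acetoxy group, so only the hydroxy-to-hydrogen step bears on this change, and that step stayed within the scatter. The expected step is therefore a 1.2-fold lower number from compound 2 to compound 4 (0.08 log units; within the scatter), no shift beyond the scatter, with wide uncertainty. Compound 4 is estimated to give 0.65 h in this assay, with a range from 0.3 h to 1.4 h.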

Compound 4, half-life: 0.0167 h
The estimate for compound 4 lay 39-fold (1.59 log units) above the measured number; the whole stated range lies above it.
By their numbers in this assay, from the lowest: compound 4; then compounds 1 and 2 (each within the scatter of the next); then compound 3.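

In this assay, this aromatic carbon turns out to be far from indifferent to what it carries: acetoxy in place of hydrogen gives a 47-fold lower number from compound 2 to compound 4 (1.67 log units; beyond the scatter), whereas the swap between hydroxy and hydrogen gave only a 1.4-fold higher number from compound 1 to compound 2 (0.14 log units; within the scatter). Placing an acetyl on the oxygen of the hydroxy group gives a 34-fold lower number from compound 1 to compound 4 (1.53 log units; beyond the scatter), so in this series the large drop appears only once the acetyl is present, not with the ring oxygen alone. Nothing available explains why the half-life falls so sharply.

The compounds shown leave open whether this drop is particular to acetoxy or would also appear with a longer ester such as butanoyloxy, or with acetamido or methoxy on the same carbon. They also leave open whether acetoxy would have a similar effect at another carbon of this ring.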